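The compounds below may be only part of what the source reports. "The series", "measured", "known", "first", "only" and "open" are said of these compounds alone.

Measured so far in a functional assay, with a stated time of 20 min, tested at 0.1 mM; on this read-out lower numbers stand for a weaker effect and higher numbers for a stronger effect at the one concentration tested:
compound 1 `COC(=O)c1c(O)c2ccccc2n(C)c1=O`: 8.3%
compound 2 `Cn1c(=O)c(C(=O)NCCN)c(O)c2ccccc21`: 5.6%
compound 3 `NCCNC(=O)c1c(O)c2ccccc2n(-c2ccccc2)c1=O`: 7.2%

The three numbers sit close together. Compound 2 differs from compound 1 by a number 2.7 percentage points lower from compound 1 to compound 2 (within the scatter) and from compound 3 by a number 1.6 percentage points higher from compound 2 to compound 3 (within the scatter); both steps are within the scatter, so no ordering among the three can be read from them. For the measured compounds named here, the first step exchanges the group on the carbonyl carbon, the second the group on the aromatic nitrogen.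

Compound 4 `Cn1c(=O)c(C(=O)NCCCCCCN)c(O)c2ccccc21` is the next compound. It differs from compound 2 in one place: 4-aminobutyl in place of amino on a saturated chain carbon, two bonds along the chain from an amide-type nitrogen. Neither measured step touches the length of this chain, so no direct comparison exists; what the two steps do show is that neither swapping the carbonyl substituent nor swapping the nitrogen substituent moved this assay beyond the scatter. On that basis the step from compound 2 to compound 4 is expected to be a number 0.4 percentage points higher from compound 2 to compound 4 (within the scatter), that is, nothing beyond the scatter. Compound 4 is therefore estimated at 6%, with a range from 0% to 16%.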

Compound 4, a percentage reported as activity, at one concentration (the size of the read-out at that concentration, not a potency): 3.1%
Beside the measured number, compound 4's estimate is 2.9 percentage points above it; low and high end bracket the measured number.
By their numbers in this assay, from the lowest: compounds 4, 2, 3 and 1 (each within the scatter of the next).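

In this assay putting 4-aminobutyl in place of amino on a saturated chain carbon, two bonds along the chain from an amide-type nitrogen, gives a number 2.5 percentage points lower from compound 2 to compound 4 (within the scatter). For the compounds shown here, this is the first look at the chain itself, as the earlier steps touched only the group on the carbonyl carbon and the group on the aromatic nitrogen, and compound 2 and compound 4 cannot be told apart on this read-out even though the new group brings more heavy atoms. No further measurement accompanies this result to explain it.

As far as these compounds go, whether a carboxylic acid or a longer chain in place of 4-aminobutyl would give a number beyond the scatter stays open. A single concentration also leaves open how compound 2 and compound 4 would compare at other concentrations.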